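A few compounds are considered here, and "the series" means these few. Any claim that something is new, unique, unknown or untested is made for them only; others in the source may bear on it.

Notes on the series. In a functional assay on A549 cells (Homo sapiens) for antiproliferative activity, read by MTT assay, with a stated time of 48 h (a lower number here means a stronger inhibitor, a higher number a weaker inhibitor), compound 1 `Cc1ccc(/C=C/C(=O)Nc2nnc(-c3ccc(Cl)cc3)s2)cc1` gives 1.25 ug/mL. Among the measured compounds shown here, compound 2 `COc1ccc(-c2nnc(NC(=O)/C=C/c3ccc(C)cc3)s2)cc1` gives 0.58 ug/mL, the lowest of the two numbers measured so far; the only step, a 2.2-fold lower number from compound 1 to compound 2 (0.33 log units; beyond the scatter), was modest. Compound 3 `COc1ccc(/C=C/C(=O)Nc2nnc(-c3ccc(OC)cc3)s2)cc1` differs from compound 2 in one place: methoxy in place of methyl on an aromatic carbon. For the measured compounds named here, no measured pair carries methoxy in place of methyl; the step from compound 1 to compound 2 swapped a different group on the other ring, so it bears on this change only loosely. A small step, if any, is expected in this assay. For compound 3 the estimate is 0.5 ug/mL, range 0.25 ug/mL to 1.2 ug/mL, a step of a 1.2-fold lower number from compound 2 to compound 3 (0.06 log units; within the scatter) that is expected to lie within the scatter.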

Compound 3, half-maximal inhibitory concentration: 0.52 ug/mL
Compound 3: the middle estimate sits 1.0-fold (0.02 log units) below what was measured; measured number inside the range.
By their numbers in this assay, from the lowest: compounds 3 and 2 (each within the scatter of the next); then compound 1.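

In this assay, among the compounds shown here, the change from 4-methylphenyl to 4-methoxyphenyl gives a 1.1-fold lower number from compound 2 to compound 3 (0.05 log units; within the scatter) and is the first reading at this position, since the earlier step touched only the other ring. Methyl and methoxy are not told apart here, although methoxy carries a hydrogen-bond acceptor that methyl lacks. No measurement available bears on why the two groups read alike. Open, from the compounds shown here alone, is whether this position accepts quite different groups, such as an amine, a carboxylic acid or a longer alkoxy chain. Also open, going by these compounds, is whether methyl and methoxy still read alike when the other ring carries chloro.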